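The source may report more compounds than this note shows. Statements on the series, on what has been measured and on what is new or still open speak of the compounds shown alone.

Measured so far in an ADME assay on MT2 cells (Homo sapiens) for cytotoxicity, read by XTT assay, with a stated time of 4 days; a higher number here means that more compound is tolerated, a lower number that less compound is tolerated: compound 1 `O=C(O)c1ccc(-c2noc(CCl)n2)cc1` gives 64000 nM; compound 2 `N#CSCc1nc(-c2ccc(C(=O)O)cc2)no1` gives 383000 nM; compound 3 `O=C(O)c1ccc(-c2noc(CBr)n2)cc1` gives 81900 nM.

Compound 3 stands second highest of the three numbers; compound 1 lies within the scatter of it, compound 2 clearly higher. The next step goes to compound 4 `O=C(O)c1ccc(-c2noc(CO)n2)cc1` with the change (hydroxy in place of bromo on a saturated chain carbon bound to an aromatic carbon). Among the compounds with values here, two measured steps touch the same position: a 1.3-fold higher number from compound 1 to compound 3 (0.11 log units; within the scatter) shows the two halogens as interchangeable, while a 4.7-fold lower number from compound 2 to compound 3 (0.67 log units; beyond the scatter) shows that a non-halogen group at this carbon went with a modestly higher number. Within the data shown here, no hydroxy analogue has been measured, so the analogy is loose. Compound 4 is expected to give 250000 nM (range 80000 nM to 800000 nM). The step of a 3.1-fold higher number from compound 3 to compound 4 (0.48 log units; beyond the scatter) is thus estimated as modest, upward, in line with compound 2.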

Compound 4, half-maximal cytotoxic concentration: 455000 nM
Beside the measured number, compound 4's estimate is 1.8-fold (0.26 log units) below it, within the range that was stated.
By their numbers in this assay, from the lowest: compounds 1 and 3 (each within the scatter of the next); then compounds 2 and 4 (each within the scatter of the next).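

In this assay, hydroxy on the saturated chain carbon bound to an aromatic carbon stands clear of both halogens, with a 5.6-fold higher number from compound 3 to compound 4 (0.74 log units; beyond the scatter) and a 7.1-fold higher number from compound 1 to compound 4 (0.85 log units; beyond the scatter) so the higher level is no longer tied to cyanosulfanyl alone. Against cyanosulfanyl the change stays within the scatter, with a 1.2-fold higher number from compound 2 to compound 4 (0.07 log units; within the scatter) and the four compounds split into a halogen pair and a non-halogen pair. No measurement at hand offers a reason for this split.

As far as these compounds go, whether an amine or a methoxy group at this carbon would fall with hydroxy or with the halogens stays open. So does the outcome for a longer chain carrying the hydroxy.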